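The source may report more compounds than this note shows. Statements on the series, on what has been measured and on what is new or still open speak of the compounds shown alone.

Measured in a functional assay on CAKI-1 cells (Homo sapiens) for cytotoxicity, read by sulforhodamine B assay, with a stated time of 24 h; a lower number here means a stronger inhibitor of growth, a higher number a weaker inhibitor of growth:
Compound 1 `COc1ccc(C(=O)/C=C/c2cc3ccccc3[nH]c2=O)cc1`: 3510 nM.
Compound 2 `O=C(/C=C/c1cc2ccccc2[nH]c1=O)c1ccc(O)cc1`: > 100000 nM, a limit of the assay and not a number.

Compound 2 thus stands only at a limit; no value beyond that bound is known for it. Compound 3 `O=C(/C=C/c1cc2ccccc2[nH]c1=O)c1ccc(Cl)cc1` differs from compound 2 by chloro in place of hydroxy on an aromatic carbon. Going by the values given here, the single measured step at this position, an at least 28-fold higher number from compound 1 to compound 2 (1.45 log units; beyond the scatter), places the hydroxy of compound 2 at the weak end of the series (the limit of > 100000 nM in this assay, at which 1 of the 2 values shown sits). Swapping that hydroxy for chloro is expected to move the number back toward the range of compound 1, a step of an at least 16-fold lower number from compound 2 to compound 3 (1.22 log units; beyond the scatter). Compound 3 is estimated at 6000 nM, between 1500 nM and 30000 nM.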

Compound 3, concentration for total growth inhibition: 3300 nM
Estimate against measurement, compound 3: 1.8-fold (0.26 log units) above; measured number inside the range.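

The hydroxy of compound 2 now looks like the exception at this position, not merely one of two readings: replacing it with chloro gives an at least 30-fold lower number from compound 2 to compound 3 (1.48 log units; beyond the scatter). Methoxy and chloro cannot be told apart here, with a 1.1-fold lower number from compound 1 to compound 3 (0.03 log units; within the scatter), so the two non-hydroxy groups read alike despite their different atoms. As far as these compounds go, compound 2 stands at > 100000 nM, a limit of the assay and not a number, so the full size of its step stays unknown.

From the compounds shown here alone, what separates hydroxy from methoxy and chloro remains open. An amine, a carboxylic acid or a longer chain on the oxygen at this place would show whether the weak reading belongs to hydroxy alone.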